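Reading a Proton's Hold Across One Amide Swap

This account rests on a few compounds, and the source may have more. Where it says the series, first, only, none or still open, it means among the compounds named here.

Measured so far in a physicochemical assay for acid dissociation, read by capillary electrophoresis, tested at 100 uM:
- compound 1 `O=c1c(O)c(Cc2ccccc2)c1=O`: < 2
- compound 2 `Oc1c(F)cc(Cc2ccccc2)cc1F`: 7.19
- compound 3 `CONC(=O)CCc1ccccc1`: 9.47

The entry for compound 1 is a limit of the assay, not a number. That leaves two true numbers, and compound 3 at 9.47 holds the higher one. Compound 2 at 7.19 sits lower by more than the scatter.

In compound 4 `CS(=O)(=O)NC(=O)CCc1ccccc1`, methylsulfonyl stands in place of methoxy on an amide-type nitrogen (methylsulfonyl in place of methoxy on an amide-type nitrogen). Among the compounds with values here, no measured pair shows this change, so the expectation rests on the structural change alone. A large move to a lower number in this assay, well beyond the scatter, is expected. The estimated step is a number 4.57 log units lower from compound 3 to compound 4 (beyond the scatter). The expected value for compound 4 is 4.9, with an estimated range of 4.2 to 5.6.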

Compound 4, acid dissociation constant: 4.94
For compound 4 the middle estimate is 0.04 log units below the measured one; low and high end bracket the measured number.
By their numbers in this assay, from the lowest: compound 4; then compound 2; then compound 3. At a limit, below all of these: compound 1.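

Within the data shown here, this is the first pair that differs in one place, so the rest of the molecule stays fixed and only the group on the amide-type nitrogen changes. In this assay, methylsulfonyl in place of methoxy gives a number 4.53 log units lower from compound 3 to compound 4 (beyond the scatter) and so this one position can carry a large step in the reading by itself.

Where an acetyl or phenylsulfonyl group on the same nitrogen would fall stays open, as does whether the swap moves the reading as far on a longer chain. The data shown give no cause for the size of this step.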